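This account rests on a few compounds, and the source may have more. Where it says the series, first, only, none or still open, it means among the compounds named here.

Working notes on the series, values in an ADME assay on MT4 cells (Homo sapiens) for cytotoxicity, read by MTT assay; a lower number here means that less compound is tolerated, a higher number that more compound is tolerated:

- compound 1 `O=C(CSc1nncnc1-c1ccccc1Cl)c1ccc(Cl)c(Cl)c1`: 33000 nM
- compound 2 `O=C(CSc1nncnc1-c1ccccc1Cl)Nc1ccccc1Br`: 73000 nM
- compound 3 `O=C(CSc1nncnc1-c1ccccc1Cl)c1ccc(Br)cc1Br`: 28000 nM

Compound 2 holds the highest number of the three in this assay, at 73000 nM. Both of its neighbours lie beyond the scatter, though not far: a 2.2-fold higher number from compound 1 to compound 2 (0.34 log units; beyond the scatter) and a 2.6-fold lower number from compound 2 to compound 3 (0.42 log units; beyond the scatter).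

Next is compound 4 `CC(=O)c1ccc(NC(=O)CSc2nncnc2-c2ccccc2Cl)c(Br)c1`, not yet measured, which differs from compound 2 by acetyl in place of hydrogen on an aromatic carbon. This is acetyl in place of hydrogen on an aromatic carbon, meta to a bromo group and para to a large group.

Within the data shown here, no measured step adds acetyl or any comparable group, so the evidence is indirect. The three measured steps all change the group on the carbonyl carbon. Two are modest, as shown above, and the third, a 1.2-fold lower number from compound 1 to compound 3 (0.07 log units; within the scatter), stays within the scatter. Changes at this end of the molecule have therefore moved the number only a little so far, although three compounds are a thin basis.

Since compound 2 sits at the top of this small range at 73000 nM, any drift is expected to be slightly downward. The expected step is a 1.3-fold lower number from compound 2 to compound 4 (0.12 log units; within the scatter), which is nothing beyond the scatter. The estimate for compound 4 is 55000 nM, with an expected range of 25000 nM to 110000 nM.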

Compound 4, half-maximal cytotoxic concentration: 34000 nM
Compound 4: the middle estimate sits 1.6-fold (0.21 log units) above what was measured; low and high end bracket the measured number.
By their numbers in this assay, from the lowest: compounds 3, 1 and 4 (each within the scatter of the next); then compound 2.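

In this assay, the series now shows that the number can move with a small addition to the aromatic ring, not only with an exchange of the whole group on the carbonyl carbon. Acetyl in place of hydrogen on an aromatic carbon, meta to a bromo group and para to a large group, gives a 2.1-fold lower number from compound 2 to compound 4 (0.33 log units; beyond the scatter), so this position is not silent in this assay, although the step is modest, like a 2.2-fold higher number from compound 1 to compound 2 (0.34 log units; beyond the scatter) and a 2.6-fold lower number from compound 2 to compound 3 (0.42 log units; beyond the scatter). No measurement in hand bears on the reason for this fall.

Still open, as far as these compounds go, is whether the fall belongs to acetyl itself or would follow any group on this aromatic carbon, a question that a methyl, an amine or a carboxylic acid at the same place could help to settle. Also open, from the compounds shown here alone, is whether acetyl would give a step of similar size on another carbon of this ring, or on a ring without the bromo group, as this single step comes from one parent, compound 2.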